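Halogen exchange on the anilino ring of compound 2

The source may report more compounds than this note shows. Statements on the series, on what has been measured and on what is new or still open speak of the compounds shown alone.

Two compounds of the series carry numbers in a functional assay on PC-3 cells (Homo sapiens) for cytotoxicity, read by MTT assay, with a stated time of 72 h; on this read-out higher numbers stand for weaker inhibition and lower numbers for stronger inhibition. Compound 1 `CCOc1ccccc1Nc1nc(SCc2ccc(C(F)(F)F)cc2)nc2ccccc12` gives 26200 nM. Compound 2 `Fc1ccc(Nc2nc(SCc3ccc(C(F)(F)F)cc3)nc3ccccc23)cc1` gives 7070 nM. Among the compounds with values here, compound 2 stands lowest of the two, with compound 1 as its only neighbour; the single measured step, a 3.7-fold lower number from compound 1 to compound 2 (0.57 log units; beyond the scatter), came with 4-fluorophenyl in place of 2-ethoxyphenyl on a nitrogen on an aromatic ring.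

Compound 3 `FC(F)(F)c1ccc(CSc2nc(Nc3ccc(Cl)cc3)c3ccccc3n2)cc1` is not yet measured. It differs from compound 2 by chloro in place of fluoro on an aromatic carbon, para to a large group; cut one bond further out, the difference reads 4-fluorophenyl to 4-chlorophenyl.

Within the data shown here, no measured step bears directly on this change: the step from compound 1 to compound 2 exchanges the whole substituted phenyl and says nothing about one halogen for another at the same place. Resting only on compound 2 with its 7070 nM, no step beyond the scatter is expected in this assay in either direction. The expected step is a 1.4-fold lower number from compound 2 to compound 3 (0.15 log units; within the scatter), inside the usual scatter. Compound 3 is therefore estimated at 5000 nM, in the range 1500 nM to 15000 nM.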

Compound 3, half-maximal inhibitory concentration: 7110 nM
For compound 3 the middle estimate is 1.4-fold (0.15 log units) below the measured one; low and high end bracket the measured number.
By their numbers in this assay, from the lowest: compounds 2 and 3 (each within the scatter of the next); then compound 1.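

Halogen identity at this place makes no difference that can be read in this assay: chloro in place of fluoro on an aromatic carbon, para to a large group, leaves the number unchanged within the scatter (a 1.0-fold higher number from compound 2 to compound 3 (0.00 log units; within the scatter)). The advantage over the 2-ethoxyphenyl of compound 1 therefore does not belong to fluoro alone, since 4-chlorophenyl gives a step (a 3.7-fold lower number from compound 1 to compound 3 (0.57 log units; beyond the scatter)) of the same size as 4-fluorophenyl (a 3.7-fold lower number from compound 1 to compound 2 (0.57 log units; beyond the scatter)). No measurement at hand offers an explanation for the equal numbers from fluoro and chloro.

Still open is whether any group at this place matters at all, as the compounds shown do not include the unsubstituted phenyl, nor a bromo, methyl, methoxy or amino group on the same aromatic carbon. Because the steps from compound 1 exchange the whole substituted phenyl, they also cannot separate the loss of the 2-ethoxy group from the arrival of a halogen, a question that 2-fluorophenyl, 2-chlorophenyl or 4-ethoxyphenyl would address.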